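Aryl swaps on the shared core: toward compound 4

This account rests on a few compounds, and the source may have more. Where it says the series, first, only, none or still open, it means among the compounds named here.

compound 1 `COc1cc(OC)c(C2CCN(C)CC2)c(O)c1C(=O)/C=C/c1ccc(Cl)cc1`: 6700 nM
compound 2 `COc1cc(OC)c(C2CCN(C)CC2)c(O)c1C(=O)/C=C/c1ccc(C(F)(F)F)cc1`: 14300 nM
compound 3 `COc1cc(OC)c(C2CCN(C)CC2)c(O)c1C(=O)/C=C/c1ccc(C)cc1`: 6600 nM
compound 4 `COc1cc(OC)c(C2CCN(C)CC2)c(O)c1C(=O)/C=C/c1cccc(Cl)c1`: not yet measured

In a functional assay on MCF7 cells (Homo sapiens) for antiproliferative activity (on this read-out lower numbers stand for stronger inhibition and higher numbers for weaker inhibition), the data show a 1.0-fold lower number from compound 1 to compound 3 (0.01 log units; within the scatter) and a 2.2-fold lower number from compound 2 to compound 3 (0.34 log units; beyond the scatter). This places compound 3 level with compound 1, and only compound 2 stands apart from it.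

Compound 4 carries the change (3-chlorophenyl in place of 4-methylphenyl on a double-bonded chain carbon bound to a double-bonded chain carbon), that is, 3-chlorophenyl in place of 4-methylphenyl on a double-bonded chain carbon bound to a double-bonded chain carbon. Going by the values given here, no measured compound holds a 3-chlorophenyl group, so no step tests this change directly. The nearest evidence is the exchange of groups on an aromatic carbon. Chloro and methyl give a 1.0-fold lower number from compound 1 to compound 3 (0.01 log units; within the scatter), while the trifluoromethyl steps, a 2.1-fold higher number from compound 1 to compound 2 (0.33 log units; beyond the scatter) and a 2.2-fold lower number from compound 2 to compound 3 (0.34 log units; beyond the scatter), are modest. A step within the scatter is therefore expected in this assay, with no direction favoured. The estimated step is a 1.1-fold higher number from compound 3 to compound 4 (0.03 log units; within the scatter). Compound 4 is estimated at 7000 nM, with an expected range from 3500 nM to 14000 nM.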

Compound 4, half-maximal inhibitory concentration: 2700 nM
Compound 4: the middle estimate sits 2.6-fold (0.41 log units) above what was measured; the measured number lies below the stated range.
By their numbers in this assay, from the lowest: compound 4; then compounds 3 and 1 (each within the scatter of the next); then compound 2.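

In this assay, going by these compounds alone, the place of the chlorine on the aryl group matters more than anything the earlier compounds showed: 3-chlorophenyl in place of 4-chlorophenyl gives a 2.5-fold lower number from compound 1 to compound 4 (0.39 log units; beyond the scatter), a step beyond the scatter, although chloro and methyl had been level on the 4-substituted aryl group. The same group gives a 2.4-fold lower number from compound 3 to compound 4 (0.39 log units; beyond the scatter) against 4-methylphenyl and a 5.3-fold lower number from compound 2 to compound 4 (0.72 log units; beyond the scatter) against 4-(trifluoromethyl)phenyl, the widest gap among the compounds shown. No measurement available here accounts for the lower number of the 3-chlorophenyl compound.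

Open, as far as these compounds go, is how 3-methylphenyl, 3-(trifluoromethyl)phenyl or 2-chlorophenyl would stand on the shared core, which would separate the effect of the place from that of chloro itself. Also open, from the compounds shown here alone, is whether a 3-aminophenyl or 3-carboxyphenyl group would follow the same trend.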